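Removing a Chloro Group from a Bis-Heterocyclic Cytotoxic Scaffold

The compounds below may be only part of what the source reports. "The series", "measured", "known", "first", "only" and "open" are said of these compounds alone.

Compound 1 `Cc1noc2c1N=C(c1ccco1)CC(c1ccccc1)C2C(c1ccccc1)C1c2onc(C)c2N=C(c2ccco2)CC1c1ccccc1`: 35.9 ug/mL
Compound 2 `Cc1noc2c1N=C(c1ccccc1)CC(c1ccccc1)C2C(c1ccc(Cl)cc1)C1c2onc(C)c2N=C(c2ccccc2)CC1c1ccccc1`: 59 ug/mL
Compound 3 `Cc1ccc(C2CC(c3ccccc3)=Nc3c(C)noc3C2C(c2ccccc2)C2c3onc(C)c3N=C(c3ccccc3)CC2c2ccc(C)cc2)cc1`: 50.1 ug/mL

Of the compounds shown here, three sharing one large core have been tested in a functional assay on MCF7 cells (Homo sapiens) for cytotoxicity, read by MTT assay, with a stated time of 48 h; on this read-out lower numbers stand for stronger inhibition and higher numbers for weaker inhibition. In this assay compound 1 gives 35.9 ug/mL, compound 2 gives 59 ug/mL and compound 3 gives 50.1 ug/mL. Compound 2 has the highest of the three numbers, but both of its neighbours lie within the usual scatter of repeated measurements: compound 3 sits closest, and compound 1 is furthest away, yet neither gap counts as a real difference. On the numbers shown, the three compounds are therefore indistinguishable.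

Compound 4 `Cc1noc2c1N=C(c1ccccc1)CC(c1ccccc1)C2C(c1ccccc1)C1c2onc(C)c2N=C(c2ccccc2)CC1c1ccccc1` has not yet been measured. It differs from compound 2 in exactly one place: hydrogen in place of chloro on an aromatic carbon. Going by the values given here, since this is the only change, and no measured pair in the set isolates this particular change, there is no direct precedent for its effect. The remaining compounds show that a larger variation elsewhere in the core moved the numbers only within the scatter, so the step from compound 2 to compound 4 is expected to be small as well, with no clear direction. The expected step is a 1.2-fold lower number from compound 2 to compound 4 (0.07 log units; within the scatter). Compound 4 is estimated at 50 ug/mL, with a likely range from 25 ug/mL to 100 ug/mL.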

Compound 4, half-maximal inhibitory concentration: 68.9 ug/mL
The estimate for compound 4 lay 1.4-fold (0.14 log units) below the measured number; measured number inside the range.
By their numbers in this assay, from the lowest: compounds 1, 3, 2 and 4 (each within the scatter of the next).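

In this assay, going by these compounds alone, the exchange of chloro for hydrogen gives a 1.2-fold higher number from compound 2 to compound 4 (0.07 log units; within the scatter) and so supplies the first pair in the set that differs in one place only, whereas the earlier compounds differed from each other in more than one place and could not isolate any single change. At this position, on a six-membered aromatic ring of carbon only and para to a large group, the step from 4-chlorophenyl to phenyl therefore leaves compound 4 indistinguishable from compound 2, so the chloro group is not required for the level of cytotoxicity seen in this pair. Nothing available here accounts for the size of this step.

A single exchange at this position leaves open what other groups would do there: an amine, a carboxylic acid, a methoxy group or a longer chain could either stay within the scatter or move the number beyond it. Going by these compounds, all of these numbers also come from this assay alone, so whether the same exchange would behave alike on another part of the shared core, or on other cells, remains unknown.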